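Cyclopropyl gives way to oxolan-3-yl

A few compounds are considered here, and "the series" means these few. Any claim that something is new, unique, unknown or untested is made for them only; others in the source may bear on it.

In a functional assay on MV4-11 cells (Homo sapiens) for antiproliferative activity, read by CellTiter-Glo, with a stated time of 72 h (a lower number here means a stronger inhibitor of growth, a higher number a weaker inhibitor of growth), compound 3 `COCCN[C@H]1CC[C@H](Nc2cc(-c3csc(NCC4CC4)n3)c(Cl)cn2)CC1` gives 740 nM, within the scatter of compound 2 `COCCCN[C@H]1CC[C@H](Nc2cc(-c3csc(NCC4CCOCC4)n3)c(Cl)cn2)CC1` at 1090 nM. Compound 1 `O=C(N[C@H]1CC[C@H](Nc2cc(-c3csc(NCC4CCOCC4)n3)c(Cl)cn2)CC1)C1CC1` gives only a limit, > 10000 nM, and no number.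

Compound 4 `COCCN[C@H]1CC[C@H](Nc2cc(-c3csc(NCC4CCOC4)n3)c(Cl)cn2)CC1` carries oxolan-3-yl in place of the cyclopropyl of compound 3, on a saturated chain carbon bound to a nitrogen on an aromatic ring (oxolan-3-yl in place of cyclopropyl on a saturated chain carbon bound to a nitrogen on an aromatic ring). The same change reads as (oxolan-3-yl)methyl for cyclopropylmethyl.

Going by the values given here, the one measured step, an at least 9.1-fold lower number from compound 1 to compound 2 (0.96 log units; beyond the scatter), lies on an amine nitrogen and not at this place, so its size does not carry over. Among the compounds with values here, with no measured step at the changed place, the expectation rests on compound 3 at 740 nM and favours neither direction in this assay. The expected step is a 1.1-fold lower number from compound 3 to compound 4 (0.02 log units; within the scatter), which means none beyond the scatter is anticipated. For compound 4 the estimate is 700 nM, with an expected range from 220 nM to 2200 nM.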

Compound 4, concentration for 50% growth inhibition: 493 nM
Estimate against measurement, compound 4: 1.4-fold (0.15 log units) above; the range from low to high includes it.
By their numbers in this assay, from the lowest: compounds 4, 3 and 2 (each within the scatter of the next, the first and the last beyond it). At a limit, above all of these: compound 1.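

In this assay, the change at the saturated chain carbon bound to a nitrogen on an aromatic ring gives a 1.5-fold lower number from compound 3 to compound 4 (0.18 log units; within the scatter). Going by these compounds alone, this is the first reading at this place, and it shows that oxolan-3-yl, with 5 heavy atoms and 1 hydrogen-bond acceptor, can stand in for cyclopropyl with no change beyond the scatter. Nothing measured here bears on a cause for this step.

The compounds shown leave open whether the ring oxygen of oxolan-3-yl matters at all, a question that cyclopentyl, a carbon-only ring of the same size, would address. They also leave open whether an amine-bearing ring such as piperidin-4-yl, or a plain methyl, at this place would move the number beyond the scatter.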